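The compounds below may be only part of what the source reports. "The series", "measured", "known", "first", "only" and "open" are said of these compounds alone.

Within the data shown here, the three compounds measured so far share one core and differ at its far end. Compound 1 `C=C(C)[C@@H]1CC=C(Cn2cc(COc3ccc(C4NC(=O)NC(C)=C4C(C)=O)cc3)nn2)CC1` gives 78200 nM in a functional assay on NCI-H460 cells (Homo sapiens) for inhibition, read by sulforhodamine B assay, with a stated time of 48 h; a lower number here means a stronger inhibitor of growth, a higher number a weaker inhibitor of growth. Compound 2 `C=C(C)[C@@H]1CC=C(Cn2cc(COc3ccc(C4NC(=O)NC5=C4C(=O)CC(C)(C)C5)cc3)nn2)CC1`, in which that end of the core is closed into a further ring, reaches only a limit of this assay, > 100000 nM. Compound 3 `C=C(C)[C@@H]1CC=C(Cn2cc(COc3cc(C4NC(=O)NC5=C4C(=O)CC(C)(C)C5)ccc3OC)nn2)CC1`, which carries a methoxy elsewhere on the six-membered aromatic ring of carbon only, likewise gives only a limit in this assay, > 100000 nM. Compound 2 thus stands at the weak end of what has been measured: its own value is a limit, and one further value among the three shown is also a limit, namely (the limit of > 100000 nM in this assay, at which 2 of the 3 values shown sit).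

Compound 4 `C=C(C)[C@@H]1CC=C(Cn2cc(COc3ccc(C4NC(=O)NC5=C4C(=O)CC(C)(C)C5)cc3OC)nn2)CC1` is made from compound 2 by a single change: methoxy in place of hydrogen on an aromatic carbon. No step between measured compounds of this kind has been shown, so the size of the step cannot be read from the data. Given that compound 2 sits at > 100000 nM, the step is expected to be a step that the limit leaves unreadable from compound 2 to compound 4, which is no change beyond the scatter. Compound 4 is accordingly expected to give 150000 nM, between 60000 nM and 400000 nM, most likely reported again as a limit rather than a number.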

Compound 4, concentration for total growth inhibition: > 100000 nM
Compound 4: only a limit was reported (the forecaster's own chance of this, stated with the estimate: 75%); the middle value does not contradict the limit.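

Compound 2 and compound 4 both give only a limit in this assay, so no step can be read for methoxy in place of hydrogen on the aromatic carbon: the limit of > 100000 nM in this assay, at which 3 of the 4 values shown sit.

The compounds shown leave open whether this methoxy changes growth inhibition at all, and what number compound 2 or compound 4 would give in this assay.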